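This account rests on a few compounds, and the source may have more. Where it says the series, first, only, none or still open, it means among the compounds named here.

Measured so far in an assay on LtK cells with ATP-sensitive inward rectifier potassium channel 11 (Homo sapiens) as the target; on this read-out lower numbers stand for an effect already at smaller amounts and higher numbers for an effect only at larger amounts of compound:
compound 1 `C/C=C/C(=O)Nc1c(C(O)(C(F)(F)F)C(F)(F)F)ccc2ccccc12` gives 72 nM
compound 2 `Cc1ccccc1C(=O)Nc1c(C(O)(C(F)(F)F)C(F)(F)F)ccc2ccccc12` gives 5550 nM
compound 3 `O=C(Nc1c(C(O)(C(F)(F)F)C(F)(F)F)ccc2ccccc12)c1ccc(Br)cc1` gives 47 nM

Compound 3 stands lowest of the three numbers; compound 1 sits close to it, a 1.5-fold lower number from compound 1 to compound 3 (0.19 log units; within the scatter), while compound 2 lies far off, a 120-fold lower number from compound 2 to compound 3 (2.07 log units; beyond the scatter). Compound 4 `O=C(Nc1c(C(O)(C(F)(F)F)C(F)(F)F)ccc2ccccc12)c1ccc(I)cc1` carries iodo in place of bromo on an aromatic carbon. The measured steps exchange whole acyl groups, a 77-fold higher number from compound 1 to compound 2 (1.89 log units; beyond the scatter) and a 120-fold lower number from compound 2 to compound 3 (2.07 log units; beyond the scatter); none exchanges one halogen for another, so they only set the scale within which compound 4 should fall. From compound 3 to compound 4 the step is expected to stay within the scatter, a 1.2-fold lower number from compound 3 to compound 4 (0.07 log units; within the scatter). Compound 4 is therefore estimated at 40 nM in this assay, with a range from 15 nM to 130 nM.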

Compound 4, half-maximal effective concentration: 154 nM
Estimate against measurement, compound 4: 3.9-fold (0.59 log units) below; the measured number lies above the stated range.
By their numbers in this assay, from the lowest: compounds 3 and 1 (each within the scatter of the next); then compound 4; then compound 2.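

In this assay the place para to a large group responds to the halogen itself: iodo in place of bromo gives a 3.3-fold higher number from compound 3 to compound 4 (0.52 log units; beyond the scatter) and so separates two close halogen analogues. The 4-iodophenyl group still stands well clear of 2-methylphenyl with a 36-fold lower number from compound 2 to compound 4 (1.56 log units; beyond the scatter) but, unlike 4-bromophenyl, no longer matches prop-1-en-1-yl, as shown by a 2.1-fold higher number from compound 1 to compound 4 (0.33 log units; beyond the scatter) in this short set. Nothing measured here bears on the reason for the bromo to iodo step. On these data alone, whether chloro, fluoro or an amine at this place would follow the same direction remains open.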